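A few compounds are considered here, and "the series" means these few. Any claim that something is new, unique, unknown or untested is made for them only; others in the source may bear on it.

Working notes on the series

Of the compounds shown here, three of a shared core have been measured in a functional assay on MGC-803 cells (Homo sapiens) for inhibition, read by MTT assay, with a stated time of 72 h; a higher number here means a weaker inhibitor, a lower number a stronger inhibitor. Compound 1 `O=C(CSc1nc(Nc2ccccc2)c2ccccc2n1)Nc1cccc([N+](=O)[O-])c1` gives 28100 nM. Compound 2 `O=C(CSc1nc(Nc2ccccc2)c2ccccc2n1)Nc1ccc(C(F)(F)F)cc1` gives 8670 nM. Compound 3 `C=CC(=O)Nc1cccc(NC(=O)CSc2nc(Nc3cccc(Cl)c3)c3ccccc3n2)c1` gives 7830 nM, the lowest of the three numbers: compound 2 lies within the scatter of it, while compound 1 lies beyond. For the measured compounds named here, the one measured step is a 3.2-fold lower number from compound 1 to compound 2 (0.51 log units; beyond the scatter), on the amide-type nitrogen.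

Compound 4 `C=CC(=O)Nc1cccc(NC(=O)CSc2nc(Nc3ccc(Cl)cc3Cl)c3ccccc3n2)c1` has not been measured. It differs from compound 3 at the other end of the molecule: 2,4-dichlorophenyl in place of 3-chlorophenyl on a nitrogen on an aromatic ring. Going by the values given here, no measured step touches this nitrogen on an aromatic ring, so nothing in the data bears directly on the change; the only step available sits on the amide-type nitrogen and is of modest size. In the absence of a relevant step, no change beyond the scatter is expected in this assay, and the estimated step is a 1.1-fold lower number from compound 3 to compound 4 (0.05 log units; within the scatter). Compound 4 is therefore expected to give about 7000 nM, with a range from 2500 nM to 20000 nM.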

Compound 4, half-maximal inhibitory concentration: 12100 nM
The estimate for compound 4 lay 1.7-fold (0.24 log units) below the measured number, and the stated range covers the measured number.
By their numbers in this assay, from the lowest: compounds 3, 2 and 4 (each within the scatter of the next); then compound 1.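

The nitrogen on an aromatic ring now has a measured step of its own: in this assay, 2,4-dichlorophenyl in place of 3-chlorophenyl gives a 1.5-fold higher number from compound 3 to compound 4 (0.19 log units; within the scatter), which stays within the scatter. This single change alters both the number of chlorines and where they sit, so the pair cannot separate the two, and neither is shown to move the number at this position. No measurement available here explains this result.

As far as these compounds go, whether an amine or a carboxylic acid on this phenyl, or a cyclohexyl in its place, would move the number beyond the scatter remains open. Also open, from the compounds shown here alone, is whether this step would read the same with the 4-(trifluoromethyl)phenyl of compound 2 on the amide-type nitrogen.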